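The source may hold more compounds than are shown below. What is called first, only, known or untested is meant among the compounds shown, and "the series" means these compounds.

Measured so far in an assay on isolated protein for inhibition of acyl-CoA desaturase 1 (Rattus norvegicus); a lower number here means a stronger inhibitor, a higher number a weaker inhibitor:
compound 1, `CS(=O)(=O)c1ccc2nc(-c3ccc(-c4ccccc4)cc3)[nH]c2c1`: 20 nM
compound 2, `CS(=O)(=O)c1ccc2nc(-c3ccc(-c4ccc(Cl)cc4)cc3)[nH]c2c1`: a limit, > 20000 nM
compound 3, `Cc1cccc(-c2ccc(-c3nc4ccc(S(C)(=O)=O)cc4[nH]3)cc2)c1`: 319 nM

Compound 3 gives the highest of the two numbers; the nearest is compound 1, with a 16-fold higher number from compound 1 to compound 3 (1.20 log units; beyond the scatter). For compound 2 the assay reports only a limit (the limit of > 20000 nM in this assay, at which 1 of the 3 values shown sits). The step under consideration leads to compound 4, `CS(=O)(=O)c1ccc2nc(-c3ccc(-c4cccc(F)c4)cc3)[nH]c2c1`, with fluoro in place of methyl on an aromatic carbon. Going by the values given here, two measured steps bear on it. Adding a methyl to the outer ring, a 16-fold higher number from compound 1 to compound 3 (1.20 log units; beyond the scatter), and adding a chloro, an at least 1000-fold higher number from compound 1 to compound 2 (3.00 log units; beyond the scatter), both raised the number, the second to a limit (the limit of > 20000 nM in this assay, at which 1 of the 3 values shown sits). Among the compounds with values here, no measured pair sets fluoro against methyl, so the size of this step has no direct precedent. Since both substituted outer rings gave higher numbers than compound 1, and compound 4 keeps a substituent at the place where compound 3 carries its methyl, a small change in either direction, close to the scatter, is expected. The expected step is a 2.1-fold lower number from compound 3 to compound 4 (0.33 log units; beyond the scatter). Compound 4 is expected at 150 nM, within 40 nM to 600 nM.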

Compound 4, half-maximal inhibitory concentration: 21 nM
Compound 4: the middle estimate sits 7.1-fold (0.85 log units) above what was measured, outside the stated range (below it).
By their numbers in this assay, from the lowest: compounds 1 and 4 (each within the scatter of the next); then compound 3. At a limit, above all of these: compound 2.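

In this assay, fluoro at this place on the outer ring, meta to a large group, shows a 1.1-fold higher number from compound 1 to compound 4 (0.02 log units; within the scatter), so a substituent here does not by itself raise the number. Fluoro in place of methyl gives a 15-fold lower number from compound 3 to compound 4 (1.18 log units; beyond the scatter), which ties the rise seen with compound 3 to the methyl group and not to substitution as such. The 3-fluorophenyl and 4-chlorophenyl groups are separated by an at least 950-fold lower number from compound 2 to compound 4 (2.97 log units; beyond the scatter), and compound 2 stands at a limit: the limit of > 20000 nM in this assay, at which 1 of the 4 values shown sits.

That last step changes both the halogen and its place on the ring, so the share of each stays unresolved. As far as these compounds go, whether the fluoro result extends to other groups at this place, such as methoxy, an amine or a carboxylic acid, also stays open.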